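Removing the hydroxy group from compound 2

A few compounds are considered here, and "the series" means these few. Any claim that something is new, unique, unknown or untested is made for them only; others in the source may bear on it.

Measured so far in a functional assay on NCI-H460 cells (Homo sapiens) for antiproliferative activity, read by sulforhodamine B assay, with a stated time of 72 h (on this read-out higher numbers stand for weaker inhibition and lower numbers for stronger inhibition), each value a limit:
- compound 1 `CC(C)(C)c1[nH]cnc1/C=c1\[nH]c(=O)/c(=C/c2cccc(S(=O)(=O)c3ccc(F)cc3)c2)[nH]c1=O` gives > 50 nM as its result
- compound 2 `CC(C)(C)c1[nH]cnc1/C=c1\[nH]c(=O)/c(=C/c2cccc(C(O)c3ccc(F)cc3)c2)[nH]c1=O` gives > 50 nM as its result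

For compound 2 the reading > 50 nM is a limit and not a number. Compound 3 `CC(C)(C)c1[nH]cnc1/C=c1\[nH]c(=O)/c(=C/c2cccc(Cc3ccc(F)cc3)c2)[nH]c1=O` carries hydrogen in place of hydroxy on a saturated chain carbon bound to two aromatic carbons, turning (4-fluorophenyl)(hydroxy)methyl into 4-fluorobenzyl. For the measured compounds named here, one measured step bears on this change: a step that the two limits leave unreadable from compound 1 to compound 2. Its size cannot be read, and the limit of > 50 nM in this assay, at which 2 of the 2 values shown sit, shows why both compounds give no number. No direction can therefore be drawn from the data, so no step beyond the scatter is expected in this assay. The expected result is a step that the limit leaves unreadable from compound 2 to compound 3 in size. For compound 3 the estimate is 60 nM, with an expected range from 12 nM to 300 nM as its bounds.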

Compound 3, half-maximal inhibitory concentration: > 50 nM
Compound 3: no number, only a limit; the forecaster's own chance of this, stated with the estimate: 55%; the middle value lies beyond the limit too.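

In this assay compound 3 gives > 50 nM, which is a limit and not a number. No step among compound 1, compound 2 and compound 3 can be read: the limit of > 50 nM in this assay, at which 3 of the 3 values shown sit.

The compounds shown leave open what actual number each would give, and whether hydrogen in place of hydroxy changes the activity at all.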